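The compounds below may be only part of what the source reports. "The series", "measured", "known", "first", "only" and "open" are said of these compounds alone.

Compound 1 `CCOC(=O)c1ccc(NC(=O)N2CC2C#N)cc1` was tested in a functional assay on WiDr cells (Homo sapiens) for inhibition (a higher number here means a weaker inhibitor, a lower number a stronger inhibitor), where compound 1 gives 2500 nM. Two other compounds share its core. Compound 2 `CC(=O)c1cccc(NC(=O)N2CC2C#N)c1` gives 3300 nM in this assay, a number that lies within the usual scatter of that for compound 1. Compound 3 `CNC(=O)N1CC1C#N` gives 21000 nM in this assay, a number well beyond the scatter from compound 1. Compound 1 thus holds the lowest of the three numbers, though only compound 3 is clearly separated from it. Compound 4 `N#CC1CN1C(=O)Nc1ccc(C(F)(F)F)cc1` has not been measured. It differs from compound 1 in one place: trifluoromethyl in place of ethoxycarbonyl on an aromatic carbon. Among the measured compounds shown here, no measured pair shows this change, so its effect in this assay is unknown; the step from compound 1 is expected to be small, if any beyond the scatter. Compound 4 is therefore estimated at 3000 nM, between 1200 nM and 8000 nM, an expected step of a 1.2-fold higher number from compound 1 to compound 4 (0.08 log units; within the scatter).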

Compound 4, half-maximal inhibitory concentration: 1300 nM
For compound 4 the middle estimate is 2.3-fold (0.36 log units) above the measured one; low and high end bracket the measured number.
By their numbers in this assay, from the lowest: compounds 4, 1 and 2 (each within the scatter of the next, the first and the last beyond it); then compound 3.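

In this assay, replacing ethoxycarbonyl with trifluoromethyl on this aromatic carbon gives a 1.9-fold lower number from compound 1 to compound 4 (0.28 log units; within the scatter). This single-place step shows that the number does not depend on keeping the ester, or any hydrogen-bond acceptor, in the group at this position. Nothing available explains the result.

The compounds shown leave open whether an amine or a carboxylic acid on this aromatic carbon would stay within the scatter of compound 1. They also do not show what a longer chain would do here.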